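The source may hold more compounds than are shown below. What is called first, only, known or untested is meant among the compounds shown, and "the series" means these compounds.

Measured compounds:
- compound 1 `C[C@@H](Nc1c(C(=O)O)cnc2ccc(-c3cccnc3)cc12)c1ccc(Cl)cc1`: in an assay on HT-29 cells for inhibition of Serine-protein kinase ATM (Homo sapiens), read by fluorescence, with a stated time of 1 h (a higher number here means a weaker inhibitor, a lower number a stronger inhibitor), compound 1 gives > 30000 nM
- compound 2 `CCC(CC)CNc1c(C(N)=O)cnc2ccc(-c3ccncc3)cc12`: in this assay compound 2 gives 418 nM

The reading for compound 1 is the limit of > 30000 nM in this assay, at which 1 of the 2 values shown sits, which is a limit of the assay and not a number. For the measured compounds named here, compound 2 therefore stands as the only real number in this set, and it is not possible to say how far apart the two compounds lie, since compound 1 also differs from compound 2 in more than one place, so no single change can be followed between them.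

The unmeasured compound 3 `CCC(CC)CNc1c(C(N)=O)cnc2ccc(-c3ccc(C)nc3)cc12` differs from compound 2 in one place: 6-methylpyridin-3-yl in place of pyridin-4-yl on an aromatic carbon. Going by the values given here, there is no measured pair here that isolates this kind of exchange, so the size of its effect is unknown. The expectation is a modest step, most likely within or only slightly beyond the usual scatter, with no firm direction. The expected change in this assay from compound 2 to compound 3 is a 1.4-fold higher number from compound 2 to compound 3 (0.16 log units; within the scatter). For compound 3 the estimate in this assay is 600 nM, with a range from 150 nM to 3000 nM.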

Compound 3, half-maximal inhibitory concentration in the Serine-protein kinase ATM assay: 50 nM
Beside the measured number, compound 3's estimate is 12-fold (1.08 log units) above it; the whole stated range lies above it.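

In the Serine-protein kinase ATM assay compound 2 gives 418 nM and compound 3 gives 50 nM. For the compounds shown here, in the Serine-protein kinase ATM assay, putting 6-methylpyridin-3-yl in place of pyridin-4-yl on the shared core gives an 8.4-fold lower number from compound 2 to compound 3 (0.92 log units; beyond the scatter), the first single change in this set that can be followed, and it shows that the number at this position depends on the group attached there. In a physicochemical assay for lipophilicity, using the shake flask method, measured as octanol-water partition, at pH 7.4 (a higher number here means a more lipophilic compound, a lower number a more polar compound), compound 2 gives 3.3. In the physicochemical assay compound 3 gives > 4.3, which is a limit of the assay and not a number. In the physicochemical assay the same exchange gives a number at least 1.00 log units higher from compound 2 to compound 3 (beyond the scatter), so the stronger inhibitor of this pair is also the more lipophilic compound, a comparison that rests on a limit: the limit of > 4.3 in the physicochemical assay, at which 1 of the 2 values shown sits.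

The exchange changes how the ring is attached and adds a methyl in one step, so these compounds cannot say which of the two carries the step. They also leave open whether a methoxy group or an ethyl chain in place of the methyl would keep the lower number in the Serine-protein kinase ATM assay, and where such a compound would fall in the physicochemical assay.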